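A few compounds are considered here, and "the series" means these few. Any claim that something is new, unique, unknown or untested is made for them only; others in the source may bear on it.

Compound 1, `N#CC1=C(N)Oc2c(N)cc3nc4ccccc4nc3c2C12C(=O)N(Cc1cnnn1-c1cccc(Br)c1)c1ccccc12`, in an ADME assay on L02 cells (Homo sapiens) for antiproliferative activity, read by MTT assay, with a stated time of 48 h (a lower number here means a stronger inhibitor, a higher number a weaker inhibitor), gives only a limit, > 50000 nM.
Compound 2, `COc1ccc(-n2nncc2CN2C(=O)C3(C(C#N)=C(N)Oc4c(N)cc5nc6ccccc6nc5c43)c3ccccc32)cc1`, in this assay gives only a limit, > 50000 nM.
Compound 3, `N#CC1=C(N)Oc2c(N)cc3nc4ccccc4nc3c2C12C(=O)N(Cc1cnnn1-c1ccc(Cl)cc1Cl)c1ccccc12`, in this assay gives only a limit, > 50000 nM.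

Compound 3 thus stands exactly where every measured value sits, namely at the limit of > 50000 nM in this assay, at which 3 of the 3 values shown sit. The measured steps a step that the two limits leave unreadable from compound 1 to compound 2, a step that the two limits leave unreadable from compound 1 to compound 3 and a step that the two limits leave unreadable from compound 2 to compound 3 cannot be read in size or direction because each end sits at the limit of > 50000 nM in this assay, at which 3 of the 3 values shown sit; the aryl group on the aromatic nitrogen has so far shown no readable effect in this assay.

Compound 4, `Cc1cc(C)c(-n2nncc2CN2C(=O)C3(C(C#N)=C(N)Oc4c(N)cc5nc6ccccc6nc5c43)c3ccccc32)c(C)c1`, differs from compound 3 by 2,4,6-trimethylphenyl in place of 2,4-dichlorophenyl on an aromatic nitrogen. Among the compounds with values here, no measured step bears readably on this change, so the expectation is simply that compound 4 again falls at the limit. Compound 4 is therefore estimated at 60000 nM, with a range from 30000 nM to 200000 nM. The step expected from this estimate is a step that the limit leaves unreadable from compound 3 to compound 4.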

Compound 4, half-maximal inhibitory concentration: > 50000 nM
Compound 4 ended at the assay's limit; the forecaster's own chance of this, stated with the estimate: 85%; the middle value is on the limit's open side.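

The steps from compound 1, compound 2 and compound 3 to compound 4 cannot be read in size or direction: each value is a limit, not a number. The compounds shown leave open whether any aryl group on the aromatic nitrogen changes the result in this assay.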